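The source may report more compounds than this note shows. Statements on the series, on what has been measured and on what is new or still open speak of the compounds shown alone.

Compounds measured in an assay on LM cells for displacement of a labelled ligand from Neuropeptide Y receptor type 5 (Homo sapiens); on this read-out lower numbers stand for stronger inhibition and higher numbers for weaker inhibition:
Compound 1 `Nc1cccc(C2=NC(c3ccc(F)cc3)(c3ccc(F)cc3)CN2)c1` gives 300 nM.
Compound 2 `Fc1ccc(C2(c3ccc(F)cc3)CNC(c3ccncc3)=N2)cc1` gives 160 nM.

Going by the values given here, of these two numbers, compound 2 stands at 160 nM with compound 1 as its only neighbour; the step of a 1.9-fold lower number from compound 1 to compound 2 (0.27 log units; within the scatter) lies within the scatter, so the two are not separated. Compound 3 `N#Cc1cc(C2=NC(c3ccc(F)cc3)(c3ccc(F)cc3)CN2)ccn1` differs from compound 2 by cyano in place of hydrogen on an aromatic carbon. Among the compounds with values here, no measured step concerns this change; the single step from compound 1 to compound 2 swapped a different group and stayed within the scatter. The expected step of no change at the digits printed from compound 2 to compound 3 (within the scatter) is therefore small. Compound 3 is expected to give 160 nM, in a range from 60 nM to 450 nM.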

Compound 3, half-maximal inhibitory concentration: 4.8 nM
Beside the measured number, compound 3's estimate is 33-fold (1.52 log units) above it; the whole stated range lies above it.
By their numbers in this assay, from the lowest: compound 3; then compounds 2 and 1 (each within the scatter of the next).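

In this assay, going by these compounds alone, cyano in place of hydrogen on the aromatic carbon next to the ring nitrogen brings a 33-fold lower number from compound 2 to compound 3 (1.52 log units; beyond the scatter), the first step here beyond the scatter. Set against 3-aminophenyl, 2-cyanopyridin-4-yl brings a 63-fold lower number from compound 1 to compound 3 (1.80 log units; beyond the scatter), whereas pyridin-4-yl alone stayed within the scatter of that group. Nothing available explains this gain. The compounds shown leave open whether the gain is particular to cyano, as against a chlorine atom, a methyl or a carboxamide on the same carbon, and whether cyano would act alike elsewhere on the ring.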